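The source may report more compounds than this note shows. Statements on the series, on what has been measured and on what is new or still open speak of the compounds shown alone.

Compound 1 `COc1cc(-c2nnc(SCC(=O)c3ccc(Br)cc3)n2N)cc(OC)c1OC`: 9230 nM
Compound 2 `COc1cc(-c2nnc(SCC(=O)Nc3ccccc3C)n2N)cc(OC)c1OC`: > 100000 nM

In a functional assay on HCT-116 cells (Homo sapiens) for antiproliferative activity, read by MTT assay, with a stated time of 48 h (a lower number here means a stronger inhibitor, a higher number a weaker inhibitor), compound 1 gives 9230 nM. For compound 2 this assay reports only a limit, > 100000 nM, so its true value is not known (the limit of > 100000 nM in this assay, at which 1 of the 2 values shown sits). Among the compounds with values here, the one measured step, an at least 10-fold higher number from compound 1 to compound 2 (1.03 log units; beyond the scatter), exchanged the group attached to the carbonyl carbon. Compound 3 `COc1ccc(CNC(=O)CSc2nnc(-c3cc(OC)c(OC)c(OC)c3)n2N)cc1OC` differs from compound 2 by 3,4-dimethoxybenzyl in place of 2-methylphenyl on an amide-type nitrogen. Within the data shown here, no measured step changes this amide substituent, so that single step offers only a loose guide. Compound 3 is therefore expected to remain weak, with an estimated value of 60000 nM, between 10000 nM and 200000 nM, meaning an expected step of an at least 1.6-fold lower number from compound 2 to compound 3 (0.22 log units; that floor lies within the scatter).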

Compound 3, half-maximal inhibitory concentration: > 100000 nM
Compound 3 ended at the assay's limit (the forecaster's own chance of this, stated with the estimate: 55%); middle value at least 1.6-fold (0.22 log units) away from the limit.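

No step can be read from compound 2 to compound 3, because both stop at a limit: the limit of > 100000 nM in this assay, at which 2 of the 3 values shown sit.

The compounds shown leave open whether 3,4-dimethoxybenzyl or 2-methylphenyl on the amide-type nitrogen gives the stronger inhibitor.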